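The source may hold more compounds than are shown below. What is called first, only, known or untested is meant among the compounds shown, and "the series" means these compounds.

Within the data shown here, in a functional assay on A549 cells (Homo sapiens) for cytotoxicity, read by MTT assay, with a stated time of 72 h (a lower number here means a stronger inhibitor, a higher number a weaker inhibitor), two compounds sharing one core have numbers so far. Compound 1 `CNC(=O)c1cc(Oc2ccc(C3=NNC(c4ccc(F)cc4Cl)C3)cc2)ccn1` gives 13700 nM, and compound 2 `CNC(=O)c1cc(Oc2ccc(C3=NNC(c4ccccc4)C3)cc2)ccn1` gives 8600 nM. These two values lie within the scatter of each other, so compound 2 cannot be ranked apart from compound 1. Compound 3 `CNC(=O)c1cc(Oc2ccc(C3=NNC(c4ccc(Cl)c(Cl)c4)C3)cc2)ccn1` differs from compound 2 by 3,4-dichlorophenyl in place of phenyl on a saturated ring carbon; in words, it has 3,4-dichlorophenyl in place of phenyl on a saturated ring carbon. Among the measured compounds shown here, only one measured step bears on this change: a 1.6-fold lower number from compound 1 to compound 2 (0.20 log units; within the scatter). That step has phenyl in place of 2-chloro-4-fluorophenyl on a saturated ring carbon, and it stays within the scatter. For the measured compounds named here, no measured compound yet carries 3,4-dichlorophenyl, so this single step is a thin guide and gives no firm direction. No step beyond the scatter is therefore expected in this assay. The estimated change is a 1.1-fold lower number from compound 2 to compound 3 (0.03 log units; within the scatter). For compound 3 the expected value is 8000 nM, with an estimated range of 3500 nM to 18000 nM.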

Compound 3, half-maximal inhibitory concentration: 10700 nM
Compound 3: middle estimate off by 1.3-fold (0.13 log units), on the low side, and the stated range covers the measured number.
By their numbers in this assay, from the lowest: compounds 2, 3 and 1 (each within the scatter of the next).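

In this assay, a third group on the saturated ring carbon, 3,4-dichlorophenyl, joins the other two without separating from either: a 1.2-fold higher number from compound 2 to compound 3 (0.09 log units; within the scatter), and a 1.3-fold lower number from compound 1 to compound 3 (0.11 log units; within the scatter). This position has now held phenyl, 2-chloro-4-fluorophenyl and 3,4-dichlorophenyl, and the three compounds cannot be ranked apart, so the result extends what the earlier pair showed for a single substituted phenyl to a second substitution pattern, with two chlorine atoms entering in place of none on the phenyl of compound 2. No supporting data accompany these numbers that could explain them.

Going by these compounds, all three compounds carry a six-membered aromatic ring of carbon only at this position, so it remains open whether a different kind of group there, such as a pyridine ring, a carboxylic acid or an amine on a longer chain, would give a step beyond the scatter. On these data alone, it is also open whether a change elsewhere on the shared core, such as an ethyl or a longer chain in place of the methyl on the amide, would move the number further than any change at this position has so far.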